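The source may hold more compounds than are shown below. What is called first, only, known or untested is meant among the compounds shown, and "the series" means these compounds.

Of the compounds shown here, two of one series have been measured so far in a functional assay for inhibition of sodium/hydrogen exchanger (Oryctolagus cuniculus); a higher number here means a weaker inhibitor, a lower number a stronger inhibitor. Compound 1, with the structure `Cc1c(C(=O)N=C(N)N)cc(S(C)(=O)=O)c(Cl)c1C`, gives 58 nM in this assay. Compound 2, with the structure `CCC(C)c1cc(C)c(C(=O)N=C(N)N)cc1S(C)(=O)=O`, gives 8 nM. Among the compounds with values here, of the two numbers, compound 2 has the lower one; the only other value, that of compound 1, lies higher by a gap that is beyond the scatter of repeated measurements, so compound 2 is the stronger inhibitor of the pair.

Compound 3, with the structure `Cc1cc(-c2ccco2)c(S(C)(=O)=O)cc1C(=O)N=C(N)N`, has not yet been measured. It differs from compound 2 in one place: furan-2-yl in place of sec-butyl on an aromatic carbon. Within the data shown here, no step between two measured compounds resembles this change, so there is no direct guide from the data to its size or direction. The change touches only one substituent of the shared core and leaves the rest untouched. Compound 3 is therefore expected to stay close to compound 2, with a small move toward a higher number that is estimated as a 1.9-fold higher number from compound 2 to compound 3 (0.27 log units; within the scatter). The estimate for compound 3 in this assay is 15 nM, within a range from 4 nM to 60 nM.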

Compound 3, half-maximal inhibitory concentration: 16 nM
Compound 3: the middle estimate sits 1.1-fold (0.03 log units) below what was measured; the measured number falls inside the stated range.
By their numbers in this assay, from the lowest: compounds 2 and 3 (each within the scatter of the next); then compound 1.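

In this assay, putting furan-2-yl in place of sec-butyl on this aromatic carbon, ortho to the methylsulfonyl group, gives a 2.0-fold higher number from compound 2 to compound 3 (0.30 log units; within the scatter), so this measurement cannot tell the two compounds apart. The earlier compounds shown here offered no step at this position, and this first one shows that, in this pair, an open chain with no ring and a five-membered aromatic ring carrying an oxygen atom give values within the scatter of each other, even though only furan-2-yl has a hydrogen-bond acceptor. Nothing available here explains why these two different groups read alike in the assay.

With only these two groups compared at this position, a single step cannot show how widely the result applies, or whether a group with a hydrogen-bond donor would behave in the same way. An amine, a carboxylic acid, a longer chain such as n-hexyl or a six-membered aromatic ring in the same place could stay within the scatter of compound 2 or move well away from it, and the compounds shown do not settle which.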